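The source may hold more compounds than are shown below. What is called first, only, known or untested is meant among the compounds shown, and "the series" means these compounds.

Measured so far:
compound 1, `CS(=O)(=O)N1CCC2(CC1)OOC1(CCCCCC1)OO2`, > 100 ug/mL
compound 2, `CCS(=O)(=O)N1CCC2(CC1)OOC1(CCCCCC1)OO2`, > 100 ug/mL
compound 3, `CCCS(=O)(=O)N1CCC2(CC1)OOC1(CCCCC1)OO2`, > 100 ug/mL

In a functional assay on Huh-7 cells (Homo sapiens) for cytotoxicity, read by MTT assay, with a stated time of 72 h (a higher number here means that more compound is tolerated, a lower number that less compound is tolerated), compound 1 gives > 100 ug/mL, which is a limit of the assay and not a number. Compound 2 gives > 100 ug/mL, likewise a limit. Compound 3 gives > 100 ug/mL, again a limit. The change from compound 1 to compound 2 is methyl in place of hydrogen on a saturated chain carbon bound to a sulfonyl sulfur, and the step it made is a step that the two limits leave unreadable from compound 1 to compound 2. The difference between the core of compound 1 and the core of compound 3 is not broken down here.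

Compound 4, `CCCCS(=O)(=O)N1CCC2(CC1)OOC1(CCCCC1)OO2`, is not yet measured in this assay. It differs from compound 3 by methyl in place of hydrogen on a saturated chain carbon, three bonds along the chain from a sulfonyl sulfur. This is the same kind of change as from compound 1 to compound 2, not the same: there the entering methyl sits on a saturated chain carbon bound to a sulfonyl sulfur, here on a saturated chain carbon three bonds along the chain from a sulfonyl sulfur.

For the measured compounds named here, for compound 4 the expectation rests on (the limit of > 100 ug/mL in this assay, at which 3 of the 3 values shown sit), since no measured compound has given a number. Compound 4 is expected to give about 150 ug/mL, with the range 60 ug/mL to 400 ug/mL. The step that the limit leaves unreadable from compound 3 to compound 4 is the estimated one, and most likely only a limit will be reported.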

Compound 4, half-maximal cytotoxic concentration: > 100 ug/mL
Compound 4: no number, only a limit (the forecaster's own chance of this, stated with the estimate: 85%); the middle value does not contradict the limit.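

Compound 3 and compound 4 both stand at a limit of the assay and not at a number, so the step between them cannot be read. The compounds shown leave open what concentration any of them would need to show cytotoxicity, and whether the chain or the core has any bearing on it: the limit of > 100 ug/mL in this assay, at which 4 of the 4 values shown sit.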